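This account rests on a few compounds, and the source may have more. Where it says the series, first, only, none or still open, it means among the compounds named here.

Measured so far:
- compound 1 `NS(=O)(=O)c1ccc(Nc2nccc(Nc3ccc4nc[nH]c4c3)n2)cc1`: > 25000 nM
- compound 2 `Cc1cccc(Nc2nccc(Nc3ccc4nc[nH]c4c3)n2)c1`: 20000 nM
- compound 3 `Cc1cccc(Nc2ncc(Cl)c(Nc3ccc4nc[nH]c4c3)n2)c1`: 7400 nM

All three were tested in an ADME assay on HepG2 cells (Homo sapiens) for inhibition, read by fluorescence and resazurin assay, with a stated time of 72 h; on this read-out lower numbers stand for stronger inhibition and higher numbers for weaker inhibition. In this assay compound 1 reaches only a limit of the assay, > 25000 nM, and no number. Compound 2 gives 20000 nM in this assay, and compound 3 gives 7400 nM. Compounds 2 and 3 differ in one place: chloro in place of hydrogen on an aromatic carbon. That change produced a 2.7-fold lower number from compound 2 to compound 3 (0.43 log units; beyond the scatter), a step that the measurements call modest but beyond the usual scatter.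

Compound 1 and compound 2 have different cores, and the difference between the two cores is not broken down here. Compound 4 `NS(=O)(=O)c1ccc(Nc2ncc(Cl)c(Nc3ccc4nc[nH]c4c3)n2)cc1` has not yet been measured. It stands to compound 1 as compound 3 stands to compound 2: chloro in place of hydrogen on an aromatic carbon. The two surroundings are not described word for word alike, since in one case the chloro is para to a (3-methylphenyl)amino group and in the other para to a large group, so this is the same kind of change rather than the same one.

Going by the values given here, only one example of the step exists, and the starting point for compound 4 is a limit rather than a number, as the limit of > 25000 nM in this assay, at which 1 of the 3 values shown sits, shows. Compound 4 is therefore expected to move by about an at least 1.6-fold lower number from compound 1 to compound 4 (0.22 log units; that floor lies within the scatter), resting on the step of a 2.7-fold lower number from compound 2 to compound 3 (0.43 log units; beyond the scatter). In this assay compound 4 is expected to give around 15000 nM, plausibly anywhere between 5000 nM and 50000 nM.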

Compound 4, half-maximal inhibitory concentration: 7800 nM
Estimate against measurement, compound 4: 1.9-fold (0.28 log units) above; low and high end bracket the measured number.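

Carried to a second core, chloro in place of hydrogen on an aromatic carbon again lowers the number in this assay, with an at least 3.2-fold lower number from compound 1 to compound 4 (0.50 log units; beyond the scatter). Set beside the earlier step, this shows the same direction on both cores, though not whether the two steps match in size: the same change on two cores in this assay, a 2.7-fold lower number (0.43 log units; beyond the scatter) from compound 2 to compound 3 and an at least 3.2-fold lower number (0.50 log units; beyond the scatter) from compound 1 to compound 4; the limit leaves it open whether they differ Compound 1 gives only a limit of the assay, > 25000 nM, not a number, and two pairs of compounds show nothing about how the change would behave on any further core.

At this place on the ring, the compounds shown carry only hydrogen or chloro, so it stays open whether fluoro, bromo, methyl or a nitrile there would lower the number in the same way. On these data alone, on the other side of the molecule, only a methyl and a sulfonamide appear, so it also stays open how the chloro step would behave with an amine or a carboxylic acid in their place.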